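The source may hold more compounds than are shown below. What is called first, only, known or untested is meant among the compounds shown, and "the series" means these compounds.

The compounds measured so far:
compound 1, `CC1=CC[C@H](C(C)C)c2cc(C)c(OC(=O)c3ccc(C)cc3)cc21`: 100%
compound 2, `CC1=CC[C@H](C(C)C)c2cc(C)c(OC(=O)c3ccc(C(F)(F)F)cc3)cc21`: 9%
compound 3, `CC1=CC[C@H](C(C)C)c2cc(C)c(OC(=O)c3ccc(Cl)cc3)cc21`: 58.9%

These three share one core and differ in a single group on the aromatic ring of the ester. In a functional assay on K562 cells (Homo sapiens) for antiproliferative activity, read by sulforhodamine B assay, with a stated time of 48 h, tested at 50 uM (a higher number here means more inhibition at the concentration tested (going by the name of the read-out), a lower number less inhibition), compound 1 gives the highest number of the three, and compound 3 stands second, with compound 1 nearest (a number 41.1 percentage points lower from compound 1 to compound 3 (beyond the scatter)) and compound 2 furthest (a number 49.9 percentage points higher from compound 2 to compound 3 (beyond the scatter)). Compound 4, `CC1=CC[C@H](C(C)C)c2cc(C)c(OC(=O)c3cccc([N+](=O)[O-])c3)cc21`, is not yet measured. It differs from compound 3 in one place: 3-nitrophenyl in place of 4-chlorophenyl on a carbonyl carbon. Among the measured compounds shown here, no measured step brings in a nitro group, so none bears on this change directly. The two steps that alter the same aromatic ring were both large, so a step beyond the scatter is expected here too, though its direction is uncertain; both measured swaps away from methyl lowered the number, so a drop from compound 3 is judged somewhat more likely than a rise. The estimate for compound 4 in this assay is 45%, within 10% to 85%, which means a step of a number 13.9 percentage points lower from compound 3 to compound 4 (beyond the scatter) is expected.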

Compound 4, a percentage reported as inhibition, at one concentration (the size of the read-out at that concentration, not a potency): 15.9%
Estimate against measurement, compound 4: 29.1 percentage points above, and the stated range covers the measured number.
By their numbers in this assay, from the lowest: compounds 2 and 4 (each within the scatter of the next); then compound 3; then compound 1.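

In this assay, replacing 4-chlorophenyl with 3-nitrophenyl on the carbonyl carbon gives a number 43 percentage points lower from compound 3 to compound 4 (beyond the scatter) and the change from the 4-methylphenyl ester gives a number 84.1 percentage points lower from compound 1 to compound 4 (beyond the scatter) so every replacement of that ester seen so far lowers the number, and compound 2 and compound 4 lie within the scatter of each other. This step changes both the group and where it sits on the ring, so it cannot show which of the two matters. Nothing available explains these differences.

As far as these compounds go, it remains open whether a nitro group placed as the chloro sits in 4-chlorophenyl would give a similar number to compound 4. From the compounds shown here alone, it is also open whether a methoxy group or an amine on this ring could retain the inhibition seen with compound 1.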